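Changing the benzyl substituent on a xanthine-like adenosine ligand

The source may hold more compounds than are shown below. What is called first, only, known or untested is meant among the compounds shown, and "the series" means these compounds.

Measured so far:
- compound 1, `CCCn1c(=O)c2nc(-c3cnn(Cc4c(F)cccc4F)c3)[nH]c2n(CCC)c1=O`: 390 nM
- compound 2, `CCCn1c(=O)c2nc(-c3cnn(Cc4cc(Cl)ccc4Cl)c3)[nH]c2n(CCC)c1=O`: 29 nM
- compound 3, `CCCn1c(=O)c2nc(-c3cnn(Cc4c(F)cc(F)cc4F)c3)[nH]c2n(CCC)c1=O`: 650 nM

All three compounds share the same core and differ only in the substituted phenyl ring carried on a saturated chain carbon bound to an aromatic nitrogen. In an in vitro assay on HEK293 cells for displacement of a labelled ligand from adenosine receptor A2b (Homo sapiens) (a lower number here means a stronger inhibitor, a higher number a weaker inhibitor), compound 3 gives 650 nM, the highest number of the three. Compound 1 lies close to it, since a 1.7-fold higher number from compound 1 to compound 3 (0.22 log units; within the scatter), but compound 2 is far away, as a 22-fold higher number from compound 2 to compound 3 (1.35 log units; beyond the scatter) shows.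

Compound 4, `CCCn1c(=O)c2nc(-c3cnn(Cc4ccc(F)c(C(F)(F)F)c4)c3)[nH]c2n(CCC)c1=O`, has not yet been tested. It differs from compound 3 in one place: 4-fluoro-3-(trifluoromethyl)phenyl in place of 2,4,6-trifluorophenyl on a saturated chain carbon bound to an aromatic nitrogen.

Among the measured compounds shown here, two measured steps bear on this change. The step of a 13-fold lower number from compound 1 to compound 2 (1.13 log units; beyond the scatter) and the step of a 22-fold higher number from compound 2 to compound 3 (1.35 log units; beyond the scatter) both show that swapping the substitution pattern of this phenyl ring can move the number by a large amount, and in both cases the ring bearing groups in the 2,5-arrangement gave the lowest number. Compound 4 carries its two groups in a new arrangement that resembles none of the three measured rings exactly, so a large movement in either direction is possible; a lower number than for compound 3 is expected, but with wide uncertainty.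

For compound 4 the expected result in this assay is 150 nM, within a range of 35 nM to 650 nM, which corresponds to an expected step of a 4.3-fold lower number from compound 3 to compound 4 (0.64 log units; beyond the scatter).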

Compound 4, inhibition constant: 640 nM
The estimate for compound 4 lay 4.3-fold (0.63 log units) below the measured number, within the range that was stated.
By their numbers in this assay, from the lowest: compound 2; then compounds 1, 4 and 3 (each within the scatter of the next).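

In this assay, the step of a 1.0-fold lower number from compound 3 to compound 4 (0.01 log units; within the scatter) shows that 4-fluoro-3-(trifluoromethyl)phenyl and 2,4,6-trifluorophenyl cannot be told apart at this position, even though the entering group has 11 heavy atoms against 9 and a different substitution pattern. The step of a 1.6-fold higher number from compound 1 to compound 4 (0.22 log units; within the scatter) is also within the scatter, while the step of a 22-fold higher number from compound 2 to compound 4 (1.34 log units; beyond the scatter) is large, so compounds 1, 3 and 4 now form a group of similar numbers and compound 2 alone stands well apart with the lowest number. Among these four compounds, every ring carrying only fluorine-containing substituents falls in the weaker group and the one ring with chlorine does not, with no exception, but no measurement shown here explains this split.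

Compound 2 differs from the others both in having chlorine and in the arrangement of the substituents on its ring, so the compounds shown leave open which of the two goes with its low number. A 2,5-difluorophenyl ring would separate these two features, and a 3-chlorophenyl ring or a benzyl ring bearing an amine or a carboxylic acid would show how far the result extends.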